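Extending an Ester Chain on a Largely Stable Core

The source may hold more compounds than are shown below. What is called first, only, known or untested is meant among the compounds shown, and "the series" means these compounds.

Measured so far in a physicochemical assay for metabolic stability, read by LC-MS, in phosphate buffer, with a stated time of 3 h, at pH 7.4, tested at 50 uM; a higher number here means that more of the compound is left, a lower number that less of the compound is left:
compound 1 `Cc1oc(=O)oc1COC(=O)N1C[C@@H]2C[C@H]1C(=O)Nc1cccc(c1)C(=O)OCc1oc(=O)oc1COC(=O)C1=C(S2)[C@H](C)[C@@H]2[C@@H]([C@@H](C)O)C(=O)N12` gives > 95%.
compound 2 `CCOC(=O)C1=C(S[C@@H]2CN[C@H](C(=O)Nc3cccc(C(=O)OCC)c3)C2)[C@H](C)[C@@H]2[C@@H]([C@@H](C)OC(C)=O)C(=O)N12` gives > 95%.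
compound 3 `CCCCCCCCCCCCCCCCOC(=O)C1=C(S[C@@H]2CN[C@H](C(=O)Nc3cccc(C(=O)OCCCCCCCCCCCCCCCC)c3)C2)[C@H](C)[C@@H]2[C@@H]([C@@H](C)O)C(=O)N12` gives > 95%.

The reading for compound 1 is a limit of the assay, not a number. The reading for compound 2 is also a limit. The reading for compound 3 is a limit as well. Compound 2 therefore cannot be placed above or below its two companions: all three readings sit at the same point, (the limit of > 95% in this assay, at which 3 of the 3 values shown sit), and within that set compound 2 is neither more nor less stable than the others as far as these numbers can tell.

Compound 4 `CCOC(=O)C1=C(S[C@@H]2CN[C@H](C(=O)Nc3cccc(C(=O)OCC)c3)C2)[C@H](C)[C@@H]2[C@@H]([C@@H](C)OC(=O)CC)C(=O)N12` is the next compound to be examined. It differs from compound 2 in one place only: methyl in place of hydrogen on a saturated chain carbon bound to a carbonyl carbon. For the measured compounds named here, no pair of measured compounds differs by a single change, so there is no measured step to lean on. Given that compound 2 already sits at the limit in this assay, the expected step is none beyond the usual scatter, a step that the limit leaves unreadable from compound 2 to compound 4. The estimate for compound 4 in this assay is 97%, within a range from 90% to 100%.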

Compound 4, percent of the compound remaining: > 95%
Compound 4 ended at the assay's limit; the forecaster's own chance of this, stated with the estimate: 85%; the middle value does not contradict the limit.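

In this assay compound 4 gives > 95%, which is a limit of the assay and not a number. Compound 2 also gives only a limit, so no step can be read for the change from acetoxy to propanoyloxy between compound 2 and compound 4. The compounds shown leave open whether any of them differs in stability at all, since every reading sits together: the limit of > 95% in this assay, at which 4 of the 4 values shown sit.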